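The source may report more compounds than this note shows. Statements on the series, on what has been measured and on what is new or still open speak of the compounds shown alone.

Two compounds of this series have numbers in an assay on isolated protein for inhibition of Intestinal-type alkaline phosphatase (Bos taurus), read by spectrophotometry, with stated times of 7 min and 15 min; a lower number here means a stronger inhibitor, a higher number a weaker inhibitor. Compound 2 `COc1ccc(Cn2c(-c3ccc(C)cc3)c(Br)c(=O)c3cc([N+](=O)[O-])ccc32)cc1` gives 2430 nM. Compound 1 `COc1ccc(C(C)n2c(-c3ccc(C)cc3)cc(=O)c3cc([N+](=O)[O-])ccc32)cc1` gives 4750 nM, and the two numbers lie within the usual scatter of each other, so no order between them can be drawn. Compound 3 `Cc1ccc(-c2c(Br)c(=O)c3cc([N+](=O)[O-])ccc3n2C(C)c2ccccc2)cc1` is not yet measured; it differs from compound 2 by 1-phenylethyl in place of 4-methoxybenzyl on an aromatic nitrogen. Going by the values given here, no measured pair shows this change alone, so no step beyond the scatter is expected in this assay. Compound 3 is estimated at 3000 nM, range 1000 nM to 9000 nM, an expected step of a 1.2-fold higher number from compound 2 to compound 3 (0.09 log units; within the scatter).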

Compound 3, half-maximal inhibitory concentration: 2470 nM
For compound 3 the middle estimate is 1.2-fold (0.08 log units) above the measured one; the range from low to high includes it.
By their numbers in this assay, from the lowest: compounds 2, 3 and 1 (each within the scatter of the next).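

Going by these compounds alone, on the aromatic nitrogen, 1-phenylethyl in place of 4-methoxybenzyl gives a 1.0-fold higher number from compound 2 to compound 3 (0.01 log units; within the scatter) in this assay, the first reading of this change alone. The hydrogen-bond acceptor counted on 4-methoxybenzyl leaves with this swap, yet the assay does not separate the two compounds. No supporting data on hand bear on this result.

As far as these compounds go, whether an amine or a carboxylic acid on the benzyl ring, or a longer chain on the aromatic nitrogen, would read beyond the scatter remains open. The contribution of the bromo group also remains open, as no pair shown differs there alone.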